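Working notes on the step from compound 2 to compound 3

A few compounds are considered here, and "the series" means these few. Any claim that something is new, unique, unknown or untested is made for them only; others in the source may bear on it.

Measured so far in a functional assay on the whole organism (strain Wistar) for inhibition, with Rattus norvegicus as the target, read by paw edema, with stated times of 30 min and 0.5 h, at a dose of 20 mg/kg; a higher number here means more inhibition at the dose given (going by the name of the read-out), a lower number less inhibition:
compound 1 `CCOC(=O)C1=C(C)NC(C)=C(C(=O)OCC)C1c1ccc(OCC(=O)NNC(=O)c2ccc(C)cc2)cc1` gives 16.7%
compound 2 `CCOC(=O)C1=C(C)NC(C)=C(C(=O)OCC)C1c1ccc(OCC(=O)NNC(=O)c2sccc2Cl)cc1` gives 10.6%

Among the compounds with values here, only one step is available between the measured compounds, a number 6.1 percentage points lower from compound 1 to compound 2 (within the scatter), an exchange of one aromatic ring for another on the carbonyl carbon. Compound 2 and compound 1 therefore sit within the scatter of each other, and no ordering between them can be read from this assay.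

Compound 3 `CCOC(=O)C1=C(C)NC(C)=C(C(=O)OCC)C1c1ccc(OCC(=O)NNC(=O)CCC(=O)O)cc1` differs from compound 2 as follows: 2-carboxyethyl in place of 3-chlorothiophen-2-yl on a carbonyl carbon

Within the data shown here, no measured step bears directly on this change. Among the measured compounds shown here, the one step in hand replaced a ring with a ring and stayed within the scatter; here a ring leaves and an open chain with a carboxylic acid enters, which no measured pair covers. The default expectation is therefore a step of a number 4.4 percentage points higher from compound 2 to compound 3 (within the scatter) that stays within the scatter, with a wide range to allow for either direction. For compound 3 the estimate is 15%, with a range from 0% to 35%.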

Compound 3, a percentage reported as inhibition, in the whole organism at one dose (the size of the read-out at that dose, not a potency): 34.9%
The estimate for compound 3 lay 19.9 percentage points below the measured number, and the stated range covers the measured number.
By their numbers in this assay, from the lowest: compounds 2 and 1 (each within the scatter of the next); then compound 3.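

At this position, on a carbonyl carbon whose other neighbour is an amide-type nitrogen, the earlier exchange of one aromatic ring for another left no readable order, whereas exchanging 3-chlorothiophen-2-yl for the open 2-carboxyethyl chain in this assay gives a number 24.3 percentage points higher from compound 2 to compound 3 (beyond the scatter). Exchanging 4-methylphenyl for the same chain gives a number 18.2 percentage points higher from compound 1 to compound 3 (beyond the scatter), so the position does respond to the group placed on it, and compound 3 stands apart from both ring-bearing compounds, which remain within the scatter of each other. Nothing at hand accounts for this gain.

The compounds shown leave open whether the step follows the loss of the aromatic ring, the arrival of the carboxylic acid, or the two together, as both change at once in compound 3. A plain alkyl chain without the carboxylic acid, a ring bearing a carboxylic acid, or a longer chain ending in a carboxylic acid would separate these readings, and the single dose says nothing about how the response changes with dose.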